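A few compounds are considered here, and "the series" means these few. Any claim that something is new, unique, unknown or untested is made for them only; others in the source may bear on it.

Series notes. Compound 3 `Cc1ccc(NC(=O)NC(=O)c2ccc(OCc3ccccc3)cc2)cc1-c1nc2ccccc2[nH]1` carries a benzyloxy group; in a functional assay on MNK45 cells (Homo sapiens) for inhibition, read by MTT assay, with a stated time of 48 h (on this read-out higher numbers stand for weaker inhibition and lower numbers for stronger inhibition), compound 3 gives 35100 nM. Compound 1 `Cc1ccc(NC(=S)NC(=O)c2ccc(OCc3cccc(Cl)c3)cc2)cc1-c1nc2ccccc2[nH]1` gives 43300 nM in this assay, a number within the scatter of that of compound 3, so the two cannot be told apart. Compound 2 `Cc1ccc(NC(=S)NC(=O)c2ccc(OCc3ccc(Cl)cc3Cl)cc2)cc1-c1nc2ccccc2[nH]1` gives 5300 nM in this assay, the lowest of the three numbers, and compound 3 lies beyond the scatter above it. Among the measured compounds shown here, the one measured step between compounds differing in a single place is an 8.2-fold lower number from compound 1 to compound 2 (0.91 log units; beyond the scatter), a move from 3-chlorophenyl to 2,4-dichlorophenyl.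

Compound 4 `Cc1ccc(NC(=O)NC(=O)c2ccc(OCc3cccc(Cl)c3Cl)cc2)cc1-c1nc2ccccc2[nH]1` is not yet measured; its change from compound 3 is 2,3-dichlorophenyl in place of phenyl on a saturated chain carbon bound to an oxygen on an aromatic ring. For the measured compounds named here, no measured pair isolates this exact change, and no measured pair sets an unsubstituted phenyl against a chlorinated one. Going by the values given here, the step of an 8.2-fold lower number from compound 1 to compound 2 (0.91 log units; beyond the scatter) is the only guide: adding chlorine to the benzyl ring lowered the number by a modest margin. A step in the same direction and of similar size is expected here, a 5.0-fold lower number from compound 3 to compound 4 (0.70 log units; beyond the scatter). Compound 4 is therefore estimated at 7000 nM, with a range from 2500 nM to 25000 nM.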

Compound 4, half-maximal inhibitory concentration: 87000 nM
Estimate against measurement, compound 4: 12-fold (1.09 log units) below, and the stated range ends below it.
By their numbers in this assay, from the lowest: compound 2; then compounds 3, 1 and 4 (each within the scatter of the next, the first and the last beyond it).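

At the benzyl position, chlorine does not lower the number in every setting: replacing phenyl with 2,3-dichlorophenyl gives a 2.5-fold higher number from compound 3 to compound 4 (0.39 log units; beyond the scatter) in this assay. This runs opposite to an 8.2-fold lower number from compound 1 to compound 2 (0.91 log units; beyond the scatter), so the earlier step from 3-chlorophenyl to 2,4-dichlorophenyl does not carry over as a general chlorine trend, and compound 4 goes against any such pattern. Nothing available explains the rise in compound 4.

The two steps differ both in the chlorine pattern and in the carbonyl of compounds 3 and 4 versus the thiocarbonyl of compounds 1 and 2, so the compounds shown cannot separate these two changes. Also open, going by these compounds, is how a single chlorine, a methoxy group or a pyridine ring in place of the phenyl would read on the carbonyl series.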